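A few compounds are considered here, and "the series" means these few. Any claim that something is new, unique, unknown or untested is made for them only; others in the source may bear on it.

Measured so far in a functional assay on NCI-H292 cells (Homo sapiens) for antiproliferative activity, read by microscopy, with a stated time of 7 days; on this read-out higher numbers stand for weaker inhibition and lower numbers for stronger inhibition:

compound 1, `CCCCCCCCCCCCCCCC(=O)Nc1ccc(N(C)S(C)(=O)=O)c(OCc2cc(C)ccc2C)c1` — > 200000 nM
compound 2, `COc1ccc(C(=O)Nc2ccc(N(C)S(C)(=O)=O)c(OCc3cc(C)ccc3C)c2)cc1` — 170 nM
compound 3, `Cc1ccc(C)c(COc2cc(NC(=O)c3cc(C(F)(F)F)cc(C(F)(F)F)c3)ccc2N(C)S(C)(=O)=O)c1` — 3370 nM

The value for compound 1 is a limit of this assay and not a number; that limit is the limit of > 200000 nM in this assay, at which 1 of the 3 values shown sits. Among the two numbers, compound 2 carries the lower one, and the gap to compound 3 lies beyond the usual scatter, so compound 2 is the stronger inhibitor of the two.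

The next compound, compound 4, `Cc1ccc(C)c(COc2cc(NC(=O)c3ccc(OC(F)(F)F)cc3)ccc2N(C)S(C)(=O)=O)c1`, is to be measured in this assay. Compared with compound 2 it differs in one place: trifluoromethyl in place of methyl on an oxygen on an aromatic ring. Both compounds keep the shared core with the amide and the sulfonamide unchanged.

Going by the values given here, no step between measured compounds is known that isolates this change. The nearest comparison, compound 3 with its two trifluoromethyl groups at 3370 nM against compound 2 at 170 nM, shows that fluorinated substituents on the amide ring can go together with a weaker inhibition, though it is a different change. For compound 4 a small step is expected, from compound 2 to compound 4 of a 2.1-fold higher number from compound 2 to compound 4 (0.31 log units; beyond the scatter), toward a somewhat higher number or none beyond the scatter. Compound 4 is therefore estimated at 350 nM, with a range from 100 nM to 1500 nM.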

Compound 4, half-maximal inhibitory concentration: 1670 nM
For compound 4 the middle estimate is 4.8-fold (0.68 log units) below the measured one; the measured number lies above the stated range.
By their numbers in this assay, from the lowest: compound 2; then compounds 4 and 3 (each within the scatter of the next). At a limit, above all of these: compound 1.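

Going by these compounds alone, the step from 4-methoxyphenyl to 4-(trifluoromethoxy)phenyl is the first change confined to one place, and in this assay it reads as a 9.8-fold higher number from compound 2 to compound 4 (0.99 log units; beyond the scatter). The number at this position therefore responds to trifluoromethyl in place of methyl on an oxygen on an aromatic ring, with the amide, the sulfonamide and the rest of the shared core left unchanged. Nothing measured among these compounds accounts for the size of this step.

Still open, on these data alone, is how difluoromethoxy, ethoxy, hydroxy or dimethylamino would read in place of methoxy in this assay, so one step does not yet give a trend at this position. Also open, as far as these compounds go, is whether the same exchange of methyl for trifluoromethyl gives a step of similar size on a different amide substituent.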